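The source may hold more compounds than are shown below. What is called first, only, known or untested is meant among the compounds shown, and "the series" means these compounds.

Working notes on the series. Among the compounds with values here, in an ADME assay on Caco-2 cells (Homo sapiens) for permeability, read by LC-MS, in the apical to basolateral direction, with a stated time of 2 h (a higher number here means that the compound crosses the layer faster, a lower number that the compound crosses the layer more slowly), compound 1 (`COc1cc(C(=O)N2CCC(O)CC2)cc2nc(NCc3cccc(Cl)c3)oc12`) gives 71 nm/s and this is the only number available. Compound 2 (`COc1cc(C(=O)N2CC[C@H](O)[C@@H](C)C2)cc2nc(NCc3cccc(Cl)c3)oc12`) has no single number: its entry reads "not determined" (no result reported) and it therefore cannot serve as a baseline. Compound 3 (`COc1cc(C(=O)N2CC(C)C(O)CC2CCO)cc2nc(NCc3cccc(Cl)c3)oc12`) still awaits measurement. The change is 4-hydroxy-2-(2-hydroxyethyl)-5-methylpiperidin-1-yl in place of 4-hydroxy-3-methylpiperidin-1-yl on a carbonyl carbon and amounts to 4-hydroxy-2-(2-hydroxyethyl)-5-methylpiperidin-1-yl in place of 4-hydroxy-3-methylpiperidin-1-yl on a carbonyl carbon. Within the data shown here, no measured step gives the size of such a change in this assay and the expectation is correspondingly loose. Among the measured compounds shown here, the only anchor is compound 1 at 71 nm/s and a downward step from that level, modest but beyond the usual scatter, is expected. The estimated apparent permeability of compound 3 is 30 nm/s with an expected range from 10 nm/s to 80 nm/s in this assay for this measurement.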

Compound 3, apparent permeability: 9.4 nm/s
Beside the measured number, compound 3's estimate is 3.2-fold (0.50 log units) above it; measured number below the stated range.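

In this assay, within the data shown here, the substituent on the carbonyl carbon now has a measured effect: 4-hydroxy-2-(2-hydroxyethyl)-5-methylpiperidin-1-yl in place of 4-hydroxypiperidin-1-yl gives a 7.6-fold lower number from compound 1 to compound 3 (0.88 log units; beyond the scatter) and this is the first step available. The step from compound 2 to compound 3 cannot be read, as compound 2 has no reported result, so the drop can be assigned only to the whole exchange and not to the methyl or the 2-hydroxyethyl group alone. No measurement at hand offers an explanation for the step.

Still open, from the compounds shown here alone, is how much of the step belongs to each of these two groups. Also open, going by these compounds, is how a 2-aminoethyl, a carboxymethyl or a longer hydroxyalkyl chain in place of the 2-hydroxyethyl group would read in this assay.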